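Swapping chloro for methoxy on the shared core

This account rests on a few compounds, and the source may have more. Where it says the series, first, only, none or still open, it means among the compounds named here.

- compound 1 `CCCCCC(CCO)n1cnc2c(OC)ncnc21` gives > 50000 nM (a limit of the assay)
- compound 2 `CCCCCCCC(CCO)n1cnc2c(Cl)ncnc21` gives 4160 nM

Among the measured compounds shown here, in a functional assay on HCT-116 cells (Homo sapiens) for antiproliferative activity, read by MTT assay, with a stated time of 48 h (on this read-out lower numbers stand for stronger inhibition and higher numbers for weaker inhibition), compound 2 gives 4160 nM, the only actual number measured so far. Compound 1 gives > 50000 nM, which is a limit and not a number.

The next compound to be tested is compound 3 `CCCCCCCC(CCO)n1cnc2c(OC)ncnc21`. It matches compound 2 except for one change: methoxy in place of chloro on an aromatic carbon. In words, methoxy sits in place of chloro on an aromatic carbon.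

For the measured compounds named here, no measured pair of compounds isolates this swap, so any forecast rests on thin evidence. Going by the values given here, the only measured compound that already carries methoxy is compound 1, and its reading in this assay is the limit (the limit of > 50000 nM in this assay, at which 1 of the 2 values shown sits). On that basis, a step towards weaker inhibition is expected, beyond the usual scatter of repeat measurements. The estimated change is a 4.8-fold higher number from compound 2 to compound 3 (0.68 log units; beyond the scatter). For compound 3 the estimated value is 20000 nM, with an expected range of 7000 nM to 50000 nM.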

Compound 3, half-maximal inhibitory concentration: 15300 nM
Compound 3: the middle estimate sits 1.3-fold (0.12 log units) above what was measured; the measured number falls inside the stated range.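

In this assay, this pair isolates the swap on the aromatic carbon of the shared core: with the chain held constant, methoxy in place of chloro gives a 3.7-fold higher number from compound 2 to compound 3 (0.57 log units; beyond the scatter), so chloro is the better of these two groups here. The chain also counts, since with methoxy kept in place, ethyl in place of hydrogen on a saturated chain carbon, six bonds along the chain from an aromatic nitrogen, gives an at least 3.2-fold lower number from compound 1 to compound 3 (0.51 log units; beyond the scatter). The reading of compound 1 is a limit and not a number, so that step has only a minimum size: the limit of > 50000 nM in this assay, at which 1 of the 3 values shown sits.

Among the compounds shown here, these compounds compare only two groups on the aromatic carbon and only two chain lengths. No measurement here explains the difference between chloro and methoxy. As far as these compounds go, it remains open whether an amine or a bromo group at this aromatic carbon would match or improve on compound 2, and whether a longer chain would lower the number further.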